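The source may report more compounds than this note shows. Statements on the series, on what has been measured and on what is new or still open speak of the compounds shown alone.

Measured compounds:
Compound 1 `COc1ccc(-c2cnc(NC(=O)c3ccn[nH]3)n2C)cc1` gives in a toxicity assay on THP-1 cells (Homo sapiens) for inhibition (a lower number here means that less compound is tolerated, a higher number that more compound is tolerated), a value that is a limit of the assay, > 100000 nM.
Compound 2 `COc1ccc(-c2cnc(NC(=O)c3ccc(Br)cc3)n2C)cc1` gives in this assay a limit as well, > 100000 nM.
Compound 3 `COc1ccc(-c2cnc(NC(C)=O)n2C)cc1` gives in this assay likewise only a limit, > 100000 nM.
Compound 4 `COc1ccc(-c2cnc(NC(=O)c3ccno3)n2C)cc1` is not yet measured.

Compound 3 thus stands at the assay limit, where every value shown so far sits (the limit of > 100000 nM in this assay, at which 3 of the 3 values shown sit). The change to compound 4 is 1,2-oxazol-5-yl in place of methyl on a carbonyl carbon. The steps bearing on it, a step that the two limits leave unreadable from compound 2 to compound 3 and a step that the two limits leave unreadable from compound 1 to compound 3, are both unreadable between two limits, as is a step that the two limits leave unreadable from compound 1 to compound 2; no size of any change on the carbonyl carbon has become readable. No step beyond the scatter is therefore expected, and compound 4 is expected to remain at the limit, the step that the limit leaves unreadable from compound 3 to compound 4 being taken as no readable change. Compound 4 is estimated at 150000 nM, with a range from 50000 nM to 500000 nM.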

Compound 4, half-maximal cytotoxic concentration: > 100000 nM
Compound 4 was reported as a limit (the forecaster's own chance of this, stated with the estimate: 85%); the middle value does not contradict the limit.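

Compound 4 stays at the limit with compound 1, compound 2 and compound 3 in this assay, so no step among these compounds can be read: the limit of > 100000 nM in this assay, at which 4 of the 4 values shown sit. The compounds shown leave open what size any change on the carbonyl carbon has, and at what concentration any of them becomes cytotoxic.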